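Acrylamide capping of an aniline across two related cores

The source may report more compounds than this note shows. Statements on the series, on what has been measured and on what is new or still open speak of the compounds shown alone.

Measured compounds:
compound 1, `C=C(Br)C(=O)Nc1cccc(-c2cn3nc(Cc4ccccc4)sc3n2)c1`, 4200 nM
compound 2, `Nc1cccc(-c2cn3nc(Cc4ccccc4)sc3n2)c1`, 37000 nM
compound 3, `Nc1cccc(-c2cn3c(-c4ccccc4)csc3n2)c1`, 29000 nM

In a functional assay on CCRF-CEM cells (Homo sapiens) for inhibition, read by cell counting, with a stated time of 3 days (on this read-out higher numbers stand for weaker inhibition and lower numbers for stronger inhibition), compound 2 gives 37000 nM and compound 1 gives 4200 nM. The difference between them is (1-bromoethenyl)carbonyl in place of hydrogen on a nitrogen on an aromatic ring; the step it made is an 8.8-fold lower number from compound 2 to compound 1 (0.94 log units; beyond the scatter).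

Compound 3 carries a different core; the difference between the core of compound 2 and the core of compound 3 is not broken down here. In this assay compound 3 gives 29000 nM, a value that sits within the scatter of compound 2, so the two free anilines are treated as equivalent.

Compound 4, `C=C(Br)C(=O)Nc1cccc(-c2cn3c(-c4ccccc4)csc3n2)c1`, is not yet measured. It differs from compound 3 by (1-bromoethenyl)carbonyl in place of hydrogen on a nitrogen on an aromatic ring, the same change as that from compound 2 to compound 1, at the same place. Given that the two anilines read alike, the step is expected to be of similar size, estimated as an 8.3-fold lower number from compound 3 to compound 4 (0.92 log units; beyond the scatter), because the earlier change gave an 8.8-fold lower number from compound 2 to compound 1 (0.94 log units; beyond the scatter). Compound 4 is therefore expected near 3500 nM in this assay, between 1200 nM and 10000 nM.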

Compound 4, half-maximal inhibitory concentration: 2800 nM
Compound 4: the middle estimate sits 1.3-fold (0.10 log units) above what was measured; low and high end bracket the measured number.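

The (1-bromoethenyl)carbonyl change, placed on the core of compound 3, gives a 10-fold lower number from compound 3 to compound 4 (1.02 log units; beyond the scatter) in this assay and so repeats on a second core what was seen on the first. Within the data shown here, two pairs on two cores show only that the step held on these two free anilines; they do not show that it would hold on a further core, and they do not tell what lies behind the fall in the number. Set side by side, the two steps do not differ: the same change on two cores in this assay, an 8.8-fold lower number (0.94 log units; beyond the scatter) from compound 2 to compound 1 and a 10-fold lower number (1.02 log units; beyond the scatter) from compound 3 to compound 4, 1.2-fold (0.07 log units) apart, within the scatter of two such steps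

What the compounds shown leave open is whether the step belongs to the (1-bromoethenyl)carbonyl group as a whole or would also come with a plain acetyl group, or with an acryloyl group lacking the bromine, on the same nitrogen. Equally open, on these data alone, is whether the step persists when the phenyl group of compound 4 gives way to a longer chain or an amine.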